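The source may report more compounds than this note shows. Statements on the series, on what has been measured and on what is new or still open speak of the compounds shown alone.

Measured compounds:
- compound 1, `CN[C@@H](CC(C)C)CN(C(=O)[C@@H]1C[C@H]1c1ccccc1)c1ccc(-c2ccccc2)cc1` — 2 nM
- compound 2, `N[C@H](CN(C(=O)[C@@H]1C[C@H]1c1ccccc1)c1ccc(-c2ccccc2)cc1)C1CCCCC1` — 0.66 nM

In a functional assay for agonist activity at G protein-coupled receptor 88 (Homo sapiens), read by HTRF and cAMP accumulation (on this read-out higher numbers stand for an effect only at larger amounts of compound and lower numbers for an effect already at smaller amounts), compound 2 gives 0.66 nM, the lowest of the two numbers at hand. Within the data shown here, its only neighbour is compound 1, which gives 2 nM in this assay; the single measured step, a 3.0-fold lower number from compound 1 to compound 2 (0.48 log units; beyond the scatter), is modest but beyond the scatter, and it changes two things at once, the amine substitution and the group on the chain carbon.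

Compound 3, `CC(C)[C@H](N)CN(C(=O)[C@@H]1C[C@H]1c1ccccc1)c1ccc(-c2ccccc2)cc1`, differs from compound 2 by isopropyl in place of cyclohexyl on a saturated chain carbon bound to an amine nitrogen and a saturated chain carbon. Among the measured compounds shown here, no measured step isolates this change: the step from compound 1 to compound 2 replaced a branched chain group with cyclohexyl while also removing the amine methyl, so it bears on the present change only loosely. Since the direction there was toward a lower number with cyclohexyl, returning to a smaller branched group is expected to cost somewhat, without any firm anchor. Compound 3 is therefore estimated at 1.5 nM in this assay, with a range of 0.5 nM to 5 nM, which corresponds to an expected step of a 2.3-fold higher number from compound 2 to compound 3 (0.36 log units; beyond the scatter).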

Compound 3, half-maximal effective concentration: 1.1 nM
Beside the measured number, compound 3's estimate is 1.4-fold (0.13 log units) above it; the measured number falls inside the stated range.
By their numbers in this assay, from the lowest: compounds 2, 3 and 1 (each within the scatter of the next, the first and the last beyond it).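

In this assay, among these compounds, the change of cyclohexyl to isopropyl on a saturated chain carbon bound to an amine nitrogen and a saturated chain carbon, with everything else held, gives a 1.7-fold higher number from compound 2 to compound 3 (0.22 log units; within the scatter); this is the first view of that group alone, and the six-membered ring can give way to an open branched group without a step beyond the scatter. The other new pair gives a 1.8-fold lower number from compound 1 to compound 3 (0.26 log units; within the scatter), so compound 3 cannot be told apart from either neighbour, and of the three pairs only compound 1 and compound 2 remain separated beyond the scatter. Nothing at hand gives a reason for these small steps.

The compounds shown leave open whether a plain methyl, a phenyl or a tetrahydropyranyl group on this chain carbon would keep the number in the same range, since only cyclohexyl and isopropyl can be compared there directly. They also leave open what the methyl on the amine nitrogen contributes by itself, as no pair shown differs in that one place alone.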